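Replacing chloro with methoxy on a second benzothiazole amide

The source may report more compounds than this note shows. Statements on the series, on what has been measured and on what is new or still open speak of the compounds shown alone.

Of the compounds shown here, three of one series have been tested in a functional assay on U-87MG ATCC cells for cytotoxicity against U-87 MG (Homo sapiens), read by MTT assay, with a stated time of 72 h; on this read-out lower numbers stand for stronger inhibition and higher numbers for weaker inhibition. Compound 1 `O=C(Nc1nc2ccc(Cl)cc2s1)c1cn(-c2ccccc2)nc1-c1ccccc1` gives 4980 nM. Compound 2 `COc1ccc2nc(NC(=O)c3cn(-c4ccccc4)nc3-c3ccccc3)sc2c1` gives 40600 nM, and compound 3 `COc1ccc(-c2nn(-c3ccccc3)cc2C(=O)Nc2nc3ccc(Cl)cc3s2)cc1` gives 8710 nM. Compound 4 `COc1ccc(-c2nn(-c3ccccc3)cc2C(=O)Nc2nc3ccc(OC)cc3s2)cc1` has not been measured. Compound 1 and compound 3 differ in their cores by methoxy in place of hydrogen on an aromatic carbon, a change that went a 1.7-fold higher number from compound 1 to compound 3 (0.24 log units; within the scatter).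

Compound 2 arises from compound 1 by methoxy in place of chloro on an aromatic carbon, and this step went an 8.2-fold higher number from compound 1 to compound 2 (0.91 log units; beyond the scatter). Compound 4 arises from compound 3 by methoxy in place of chloro on an aromatic carbon, the same change at the same place, since the surroundings described for both are identical. Among the compounds with values here, with only this one earlier instance to go by, the step from compound 3 to compound 4 in this assay is expected to be of similar size, a 6.9-fold higher number from compound 3 to compound 4 (0.84 log units; beyond the scatter), because the earlier step of an 8.2-fold higher number from compound 1 to compound 2 (0.91 log units; beyond the scatter) was well beyond the scatter. Compound 4 is therefore estimated at 60000 nM, with a likely range from 20000 nM to 180000 nM.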

Compound 4, half-maximal inhibitory concentration: 5890 nM
Compound 4: the middle estimate sits 10-fold (1.01 log units) above what was measured; measured number below the stated range.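

In this assay, methoxy in place of chloro on an aromatic carbon did not repeat its earlier effect, since the new step is a 1.5-fold lower number from compound 3 to compound 4 (0.17 log units; within the scatter): the same change on two cores in this assay, an 8.2-fold higher number (0.91 log units; beyond the scatter) from compound 1 to compound 2 and a 1.5-fold lower number (0.17 log units; within the scatter) from compound 3 to compound 4, 12-fold (1.08 log units) apart, beyond the scatter of two such steps Methoxy in place of hydrogen on an aromatic carbon also depends on its core, with the new step being a 6.9-fold lower number from compound 2 to compound 4 (0.84 log units; beyond the scatter): the same change on two cores in this assay, a 1.7-fold higher number (0.24 log units; within the scatter) from compound 1 to compound 3 and a 6.9-fold lower number (0.84 log units; beyond the scatter) from compound 2 to compound 4, 12-fold (1.08 log units) apart, beyond the scatter of two such steps Across these four compounds, the size of each change therefore depends on the core that carries it, so a step measured on one core did not predict the step on the other, but the data do not show why, and this single comparison gives no rule for other cores.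

The compounds shown leave open whether an amine, a carboxylic acid or a longer alkoxy chain in place of chloro would depend on the core in the same way. They also leave open whether this dependence appears in any read-out other than this assay.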